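Ring-nitrogen substituent change in a Ret growth-inhibition series

This account rests on a few compounds, and the source may have more. Where it says the series, first, only, none or still open, it means among the compounds named here.

compound 1 `CC(C)n1nc(-c2cc(C3CCCCC3)on2)c2c(N)ncnc21` — 9500 nM
compound 2 `CC(C)n1nc(-c2cc(C(C)(C)C)on2)c2c(N)ncnc21` — 6120 nM
compound 3 `Nc1ncnc2c1c(-c1cc(C3CC3)on1)nn2C1CCCCC1` — 520 nM

In an assay on BaF3 cells for inhibition of proto-oncogene tyrosine-protein kinase receptor Ret (Homo sapiens), read by MTT assay, with a stated time of 48 h (on this read-out lower numbers stand for stronger inhibition of growth and higher numbers for weaker inhibition of growth), compound 3 gives the lowest number of the three, with compound 2 and compound 1 both sitting higher by margins beyond the scatter. Compound 4 `CCCCCCCn1nc(-c2cc(C3CC3)on2)c2c(N)ncnc21` differs from compound 3 by heptyl in place of cyclohexyl on an aromatic nitrogen. Among the measured compounds shown here, the only measured single-point step, a 1.6-fold lower number from compound 1 to compound 2 (0.19 log units; within the scatter), concerns a group on an aromatic carbon of the oxazole ring and leaves the ring nitrogen untouched, so it does not bear on this change. Compounds 1 and 2 differ from compound 3 in two places, so their values give no direct comparison either. With nothing measured at this position, the expected step is small and uncertain: a 1.7-fold higher number from compound 3 to compound 4 (0.24 log units; within the scatter). Compound 4 is therefore estimated at 900 nM, with a range from 250 nM to 3500 nM.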

Compound 4, concentration for 50% growth inhibition: > 10000 nM
Compound 4 was reported as a limit; the forecaster's own chance of this, stated with the estimate: 5%; middle value at least 11-fold (1.04 log units) from the limit.
By their numbers in this assay, from the lowest: compound 3; then compounds 2 and 1 (each within the scatter of the next). At a limit, above all of these: compound 4.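

On the aromatic nitrogen, heptyl in place of cyclohexyl is far from a neutral exchange: the step is an at least 19-fold higher number from compound 3 to compound 4 (1.28 log units; beyond the scatter). Among the compounds shown here, this is the first single change read at this position, and it shows that growth inhibition depends strongly on the group held there. In this assay compound 4 gives > 10000 nM, which is a limit: the limit of > 10000 nM in this assay, at which 1 of the 4 values shown sits.

Going by these compounds, whether the ring of cyclohexyl or the length of the heptyl chain governs this step stays open. A shorter chain such as butyl, or a ring such as cyclopentyl, on this nitrogen would separate the two.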